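The source may report more compounds than this note shows. Statements on the series, on what has been measured and on what is new or still open speak of the compounds shown alone.

Of the compounds shown here, three sharing one core have been measured in an ADME assay on MT4 cells (Homo sapiens) for cytotoxicity, read by MTT assay, with a stated time of 4 days; on this read-out higher numbers stand for lower toxicity in this test and lower numbers for higher toxicity in this test. Compound 1 `CC(=O)Nc1ccc2oc(-c3cccc(F)c3)cc(=O)c2c1`, which has a 3-fluorophenyl but no hydroxy group, gives 240000 nM. Compound 2 `CC(=O)Nc1ccc2oc(-c3ccccc3)c(O)c(=O)c2c1`, with a plain phenyl and the hydroxy group, gives 64700 nM. Compound 3 `CC(=O)Nc1ccc2oc(-c3ccccc3F)c(O)c(=O)c2c1`, with a 2-fluorophenyl and the hydroxy group, gives 171000 nM. Compound 3 thus stands within the scatter of compound 1 and clearly apart from compound 2.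

Compound 4 `CC(=O)Nc1ccc2oc(-c3cccc(F)c3)c(O)c(=O)c2c1` has not yet been measured. It differs from compound 3 only in where the fluorine sits on the phenyl group: 3-fluorophenyl in place of 2-fluorophenyl on an aromatic carbon. The group stands next to the ring oxygen and ortho to a hydroxy group.

For the measured compounds named here, no measured step compares two fluorine positions directly. The closest evidence is the fluoro in place of hydrogen on an aromatic carbon, which gave a 2.6-fold higher number from compound 2 to compound 3 (0.42 log units; beyond the scatter). Going by the values given here, compound 1, at 240000 nM, is the only measured compound with the 3-fluorophenyl, but it lacks the hydroxy group and is only a rough guide. No step beyond the scatter is therefore expected in this assay. The expected change is a 1.1-fold lower number from compound 3 to compound 4 (0.06 log units; within the scatter). Compound 4 is estimated at 150000 nM, with an expected range from 70000 nM to 280000 nM.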

Compound 4, half-maximal cytotoxic concentration: 26500 nM
The estimate for compound 4 lay 5.7-fold (0.75 log units) above the measured number; the whole stated range lies above it.
By their numbers in this assay, from the lowest: compound 4; then compound 2; then compounds 3 and 1 (each within the scatter of the next).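

In this assay, moving the fluorine on the phenyl group matters even though the atoms stay the same, with 3-fluorophenyl in place of 2-fluorophenyl giving a 6.5-fold lower number from compound 3 to compound 4 (0.81 log units; beyond the scatter). The earlier compounds showed fluoro in place of hydrogen only as a rise, a 2.6-fold higher number from compound 2 to compound 3 (0.42 log units; beyond the scatter), but with the 3-fluorophenyl the same kind of change runs the other way, a 2.4-fold lower number from compound 2 to compound 4 (0.39 log units; beyond the scatter), so among these hydroxy compounds its direction follows the position of the fluorine. Hydroxy in place of hydrogen on the shared core also gives a 9.1-fold lower number from compound 1 to compound 4 (0.96 log units; beyond the scatter), and with its steps to all three others beyond the scatter, compound 4 is the most toxic of the four in this test.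

The compounds shown offer no measurement that accounts for these shifts. They also leave open whether a chloro group, a methoxy group or an amine on the phenyl group would follow the 2-fluorophenyl or the 3-fluorophenyl, and whether the hydroxy group would have a similar effect alongside the 2-fluorophenyl or the plain phenyl.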